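The compounds below may be only part of what the source reports. "The series", "measured", "known", "first", "only" and "open" are said of these compounds alone.

Of the compounds shown here, three built on one shared core have been tested in an ADME assay on MT4 cells (Homo sapiens) for cytotoxicity, read by MTT assay, with a stated time of 4 days; a higher number here means that more compound is tolerated, a lower number that less compound is tolerated. Compound 1 `O=C1c2sccc2N(Cc2ccccc2)S(=O)(=O)N1Cc1ccccc1` gives 37500 nM. Compound 3 `N#Cc1ccc(CN2c3ccsc3C(=O)N(Cc3ccccc3)S2(=O)=O)cc1` gives 8500 nM in this assay, which is the lowest of the two plain numbers shown. For compound 2 `O=C1c2sccc2N(Cc2ccccc2Br)S(=O)(=O)N1Cc1ccccc1` this assay reports only a limit, > 270000 nM.

The measured steps run as follows: an at least 7.2-fold higher number from compound 1 to compound 2 (0.85 log units; beyond the scatter); a 4.4-fold lower number from compound 1 to compound 3 (0.64 log units; beyond the scatter); and an at least 31-fold lower number from compound 2 to compound 3 (1.50 log units; beyond the scatter).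

Compound 4 `N#CCN1c2ccsc2C(=O)N(Cc2ccccc2)S1(=O)=O` differs from compound 3 in one place: cyano in place of 4-cyanophenyl on a saturated chain carbon bound to a sulfonamide nitrogen in a ring. Among the compounds with values here, no measured step removes an aromatic ring, so none maps directly onto this change. The cyano group that stays in compound 4 was introduced in the step from compound 1 to compound 3, where it went with the modest drop a 4.4-fold lower number from compound 1 to compound 3 (0.64 log units; beyond the scatter). Without a closer precedent, the number for compound 4 is expected to move a little toward a higher number in this assay, as a 2.9-fold higher number from compound 3 to compound 4 (0.47 log units; beyond the scatter), but the change may also fall within the scatter. Compound 4 is therefore estimated at 25000 nM, between 8000 nM and 80000 nM.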

Compound 4, half-maximal cytotoxic concentration: 5700 nM
Beside the measured number, compound 4's estimate is 4.4-fold (0.64 log units) above it, outside the stated range (below it).
By their numbers in this assay, from the lowest: compounds 4 and 3 (each within the scatter of the next); then compound 1. At a limit, above all of these: compound 2.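

At this position, on a saturated chain carbon bound to a sulfonamide nitrogen in a ring, the whole aromatic ring of the 4-cyanobenzyl group can give way to cyanomethyl with no readable change in this assay: a 1.5-fold lower number from compound 3 to compound 4 (0.17 log units; within the scatter). Compound 4 also shows that a nitrile on this short chain goes with a drop from the plain benzyl compound, a 6.6-fold lower number from compound 1 to compound 4 (0.82 log units; beyond the scatter), as the nitrile on the benzyl ring did in compound 3. The largest step, an at least 47-fold lower number from compound 2 to compound 4 (1.67 log units; beyond the scatter), rests on a limit and not on a plain number: the limit of > 270000 nM in this assay, at which 1 of the 4 values shown sits.

As far as these compounds go, what remains open is whether the nitrile itself matters here or whether any small group would give the same reading. A plain methyl group or a short chain ending in an amine or a carboxylic acid would help separate these two possibilities.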